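This account rests on a few compounds, and the source may have more. Where it says the series, first, only, none or still open, it means among the compounds named here.

Of the compounds shown here, three from one series have been tested in a functional assay on 4T1 cells (Mus musculus) for cytotoxicity, read by MTT assay, with a stated time of 24 h; on this read-out higher numbers stand for weaker inhibition and lower numbers for stronger inhibition. Compound 1 `COc1ccc(/C=C2\CN(Cc3cn(Cc4cccc(Cl)c4)nn3)C/C(=C\c3ccc(OC)cc3)C2=O)cc1` carries a 3-chlorobenzyl group on its core, and in this assay compound 1 gives 56600 nM. Compound 3 `Cc1ccc(/C=C2\CN(Cc3cn(Cc4cccc(Cl)c4)nn3)C/C(=C\c3ccc(C)cc3)C2=O)cc1` also carries a 3-chlorobenzyl group, but on a core unlike that of compound 1, and in this assay compound 3 gives 29300 nM; the difference between the two cores is not broken down here. Compound 2 `Cc1ccc(/C=C2\CN(Cc3cn(Cc4ccc(F)cc4)nn3)C/C(=C\c3ccc(C)cc3)C2=O)cc1` shares the core of compound 3 and differs from it by one change, (4-fluorophenyl in place of 3-chlorophenyl on a saturated chain carbon bound to an aromatic nitrogen), and in this assay compound 2 gives 57200 nM. That single change made the step of a 2.0-fold higher number from compound 3 to compound 2 (0.29 log units; within the scatter). Compound 4 `COc1ccc(/C=C2\CN(Cc3cn(Cc4ccc(F)cc4)nn3)C/C(=C\c3ccc(OC)cc3)C2=O)cc1` has not yet been measured; it stands to compound 1 exactly as compound 2 stands to compound 3, through the same change at the same place, (4-fluorophenyl in place of 3-chlorophenyl on a saturated chain carbon bound to an aromatic nitrogen). Because the earlier step of a 2.0-fold higher number from compound 3 to compound 2 (0.29 log units; within the scatter) stayed within the scatter, a step of similar size is expected for compound 4, namely a 1.5-fold higher number from compound 1 to compound 4 (0.18 log units; within the scatter). In this assay compound 4 is estimated at 85000 nM, expected to fall between 40000 nM and 180000 nM.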

Compound 4, half-maximal inhibitory concentration: 49300 nM
Compound 4: middle estimate off by 1.7-fold (0.24 log units), on the high side, within the range that was stated.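

Replacing the 3-chlorobenzyl group with the 4-fluorobenzyl group on the core of compound 1 gives, in this assay, a 1.1-fold lower number from compound 1 to compound 4 (0.06 log units; within the scatter), so the new step is too small to separate from ordinary repeat variation. The step on this core can also be set beside the one seen on the core of compound 3, and the two cannot be told apart: the same change on two cores in this assay, a 2.0-fold higher number (0.29 log units; within the scatter) from compound 3 to compound 2 and a 1.1-fold lower number (0.06 log units; within the scatter) from compound 1 to compound 4, 2.2-fold (0.35 log units) apart, within the scatter of two such steps. This shows that, across these four compounds, the change behaves alike on both cores within the precision of the assay, with neither step large enough to read as a real effect; it does not show that the two cores respond identically, or that the same would hold on any other core.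

The compounds shown place only these two halogen-bearing benzyl groups on the triazole-linked position of the shared structure, so it stays open whether a longer chain, or an amine or a carboxylic acid on the phenyl ring, would move the number beyond the scatter. Whether any such group would act alike on both cores is open as well.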